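The source may hold more compounds than are shown below. What is called first, only, known or untested is meant among the compounds shown, and "the series" means these compounds.

Compound 1 `Cn1cc(-c2ccc(NC(=O)c3cn(CC4CCOCC4)cc(-c4ccc(F)cc4F)c3=O)cc2)c2c(N)ncnc21`: 501 nM
Compound 2 `CC(C)n1cc(C(=O)Nc2cc(F)c(-c3c[nH]c4ncnc(N)c34)cc2F)c(=O)c(-c2ccc(F)cc2)c1`: 13.2 nM

In a functional assay on MKN-45 cells (Homo sapiens) for antiproliferative activity, with a stated time of 72 h (on this read-out higher numbers stand for weaker inhibition and lower numbers for stronger inhibition), compound 1 has the higher number of the two, and the gap down to compound 2 lies beyond the scatter. The two differ in more than one place, so no single change can be read from them.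

Compound 3 `Cn1cc(-c2ccc(NC(=O)c3cn(CC4CCOCC4)cc(-c4ccc(C(F)(F)F)cc4)c3=O)cc2)c2c(N)ncnc21` differs from compound 1 by 4-(trifluoromethyl)phenyl in place of 2,4-difluorophenyl on an aromatic carbon, with 4-(trifluoromethyl)phenyl in place of 2,4-difluorophenyl on an aromatic carbon. Going by the values given here, no measured one-place step guides this change, so no step beyond the scatter is expected in this assay. The estimated step is a 1.2-fold higher number from compound 1 to compound 3 (0.08 log units; within the scatter). Compound 3 is estimated at 600 nM, with an expected range of 200 nM to 1800 nM.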

Compound 3, half-maximal inhibitory concentration: 826 nM
Beside the measured number, compound 3's estimate is 1.4-fold (0.14 log units) below it; the measured number falls inside the stated range.
By their numbers in this assay, from the lowest: compound 2; then compounds 1 and 3 (each within the scatter of the next).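

Going by these compounds alone, at the aromatic carbon meta to the (oxan-4-yl)methyl group, 4-(trifluoromethyl)phenyl in place of 2,4-difluorophenyl gives a 1.6-fold higher number from compound 1 to compound 3 (0.22 log units; within the scatter) in this assay as the only one-place step read so far. This position therefore tolerates this exchange of one fluorinated phenyl for another, with no step beyond the scatter on this read-out. Nothing available bears on the reason for this result.

Still open, on these data alone, is whether a group without a phenyl ring at this carbon, such as a carboxylic acid or a morpholine, would stay within the scatter of compound 1. What separates compound 2 from compound 1 also remains unresolved, as they differ in more than one place.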